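Aryl variation on the shared core: thiophen-2-yl analogue

The source may report more compounds than this note shows. Statements on the series, on what has been measured and on what is new or still open speak of the compounds shown alone.

Compound 1 `Brc1cn2ccnc2c(-c2ccc3ncn(C4CCCCC4)c3c2)n1`, compound 2 `c1cn2cc(-c3ccsc3)nc(-c3ccc4ncn(C5CCCCC5)c4c3)c2n1` and compound 3 `Clc1ccc(-c2cn3ccnc3c(-c3ccc4ncn(C5CCCCC5)c4c3)n2)cc1` share one core and differ only in the group on one aromatic carbon. In a functional assay on LOX IMVI cells (Homo sapiens) for inhibition, read by sulforhodamine B assay, with a stated time of 48 h, tested at 10 uM (on this read-out lower numbers stand for less inhibition and higher numbers for more inhibition at the one concentration tested (going by the name of the read-out)), compound 1 gives 15.2%, compound 2 gives 4.9% and compound 3 gives 14.8%. Compound 3 sits close to compound 1, the step being a number 0.4 percentage points lower from compound 1 to compound 3 (within the scatter), and its gap to compound 2, a number 9.9 percentage points higher from compound 2 to compound 3 (within the scatter), also stays inside the scatter, so no order among the three can be drawn from these numbers alone. Among the measured compounds shown here, the one step beyond the scatter is a number 10.3 percentage points lower from compound 1 to compound 2 (beyond the scatter).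

Compound 4 `c1csc(-c2cn3ccnc3c(-c3ccc4ncn(C5CCCCC5)c4c3)n2)c1` is not yet measured. Relative to compound 3 it carries thiophen-2-yl in place of 4-chlorophenyl on an aromatic carbon. For the measured compounds named here, two steps bear on this change: a number 9.9 percentage points higher from compound 2 to compound 3 (within the scatter), whose reverse direction is the closest match to a thiophene entering in place of 4-chlorophenyl, and a number 10.3 percentage points lower from compound 1 to compound 2 (beyond the scatter), in which thiophen-3-yl entered in place of bromo. Both carry the same sign, one within the scatter and one beyond it, so a modest drop in this assay is expected, about a number 7.8 percentage points lower from compound 3 to compound 4 (within the scatter). Compound 4 is therefore estimated at 7%, with an expected range from -3% to 17%. Going by the values given here, no measured pair covers the difference between thiophen-2-yl and thiophen-3-yl, so the range is kept wide.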

Compound 4, a percentage reported as inhibition, at one concentration (the size of the read-out at that concentration, not a potency): 1.07%
For compound 4 the middle estimate is 5.9 percentage points above the measured one; the range from low to high includes it.
By their numbers in this assay, from the lowest: compounds 4, 2, 3 and 1 (each within the scatter of the next, the first and the last beyond it).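

In this assay, thiophen-2-yl on this aromatic carbon, next to the ring nitrogen, gives a number 13.7 percentage points lower from compound 3 to compound 4 (beyond the scatter) as the replacement for 4-chlorophenyl, so a thiophene is now separated from 4-chlorophenyl beyond the scatter, which the thiophen-3-yl compound 2 did not show. Thiophen-2-yl also falls away from bromo, with a number 14.1 percentage points lower from compound 1 to compound 4 (beyond the scatter) in the same direction as the earlier thiophen-3-yl step, while a number 3.8 percentage points lower from compound 2 to compound 4 (within the scatter) leaves the two thiophene attachments indistinguishable here, so the low end of this small set is held by both thiophenes and compound 3 remains unseparated from compound 1. No measured data on the compounds explain why the thiophenes part from 4-chlorophenyl and bromo.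

The compounds shown leave open whether a group of another kind at this carbon, such as an amine or a carboxylic acid, would move the inhibition above the level of compound 1 and compound 3. They also leave open whether the gap between the thiophenes and 4-chlorophenyl would persist at other concentrations, since each value here comes from one concentration and gives no potency.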